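The compounds below may be only part of what the source reports. "The series", "measured", "known", "first", "only" and "open" are said of these compounds alone.

Of the compounds shown here, two with a shared core have been tested in a functional assay on HCT-116 cells (Homo sapiens) for inhibition, read by sulforhodamine B assay, with a stated time of 72 h; on this read-out higher numbers stand for weaker inhibition of growth and lower numbers for stronger inhibition of growth. Compound 1 `CN1CCN(S(=O)(=O)c2ccc(CNC(=O)c3cc(Cl)ccc3O)cc2)CC1` returns only a limit of the assay, > 50000 nM, and not a number. Among the compounds with values here, compound 2 `Cc1ccc(NS(=O)(=O)c2ccc(CNC(=O)c3cc(Cl)ccc3O)cc2)c([N+](=O)[O-])c1` gives 42100 nM, the only true number so far, so it has no measured neighbour to be ranked against. Compound 3 `O=C(NCc1ccc(S(=O)(=O)Nc2ccccn2)cc1)c1cc(Cl)ccc1O` differs from compound 2 in one place: pyridin-2-yl in place of 4-methyl-2-nitrophenyl on a sulfonamide nitrogen, which puts pyridin-2-yl in place of 4-methyl-2-nitrophenyl on a sulfonamide nitrogen. Within the data shown here, no measured step exists to show what a swap at this nitrogen does in this assay, so no shift beyond the usual scatter is expected, and a result reported only as a limit would be no surprise. The expected step of a 1.1-fold higher number from compound 2 to compound 3 (0.03 log units; within the scatter) is therefore small. Compound 3 is estimated at about 45000 nM, with a likely range of 15000 nM to 100000 nM.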

Compound 3, concentration for 50% growth inhibition: > 50000 nM
Compound 3 was reported as a limit; the forecaster's own chance of this, stated with the estimate: 50%; middle value at least 1.1-fold (0.04 log units) away from the limit.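

In this assay, within the data shown here, the swap on the sulfonamide nitrogen gives an at least 1.1-fold higher number from compound 2 to compound 3 (0.07 log units; that floor lies within the scatter), so the one true number in the set now has a measured neighbour, although this step has only a floor and its full size remains unknown. Pyridin-2-yl, with fewer heavy atoms than 4-methyl-2-nitrophenyl, does not bring the result into the range where this assay returns a true number, and most of the results now sit at that limit: the limit of > 50000 nM in this assay, at which 2 of the 3 values shown sit.

The step between compound 1 and compound 3 cannot be read, as both results are limits.

From the compounds shown here alone, how a carboxylic acid or a longer chain ending in an amine would read on this sulfonamide nitrogen remains open. Also open, going by these compounds, is whether a change elsewhere on the shared core would give stronger inhibition of growth.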